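The compounds below may be only part of what the source reports. "The series", "measured", "known", "first", "only" and "open" are said of these compounds alone.

In an ADME assay on cells (Osteoblast, Mus musculus) for cytotoxicity, read by resazurin assay (on this read-out lower numbers stand for stronger inhibition and higher numbers for weaker inhibition), compound 1 `OCCCCCC(O)c1ccc(-c2ccccc2)cc1` gives no number but only the limit of the assay, > 100000 nM. Compound 2 `Cc1cc(C(O)CCCCCO)ccc1-c1ccc(F)cc1F` likewise stops at the limit, > 100000 nM. Compound 3 `O=C(CCCCCO)c1ccc(-c2ccc(F)cc2F)cc1` also reaches only the limit, > 100000 nM. As the limit of > 100000 nM in this assay, at which 3 of the 3 values shown sit, records, every value shown is a limit, so compound 3 sits exactly where the other two sit, without a number of its own. Compound 4 `O=C(CCCCCO)c1ccc(-c2ccc(F)cc2F)cc1Cl` differs from compound 3 by chloro in place of hydrogen on an aromatic carbon. Among the compounds with values here, no step between measured compounds is known. With all three compounds at the limit, the expected step in this assay is a number no higher from compound 3 to compound 4 (the limit leaves the size open), none beyond the scatter. Compound 4 is therefore estimated at 100000 nM, between 30000 nM and 300000 nM, most probably again reported only as a limit.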

Compound 4, half-maximal inhibitory concentration: > 100000 nM
Compound 4: no number, only a limit; the forecaster's own chance of this, stated with the estimate: 80%; the middle value sits exactly at the limit.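

Within the data shown here, compound 3 and compound 4 both stop at a limit, so no step between them can be read: the limit of > 100000 nM in this assay, at which 4 of the 4 values shown sit. The compounds shown leave open what chloro in place of hydrogen on an aromatic carbon does in this assay.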